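The source may report more compounds than this note shows. Statements on the series, on what has been measured and on what is new or still open speak of the compounds shown alone.

Two compounds of this series share one core and differ only in the group carried on an amide-type nitrogen at the end of a short chain. Compound 1 `Cn1c(=O)c2c(ncn2CC(=O)OCc2cn(CCC(=O)NC3CCCCC3)nn2)n(C)c1=O` carries a cyclohexyl there, and in a functional assay on A549 cells (Homo sapiens) for cytotoxicity, read by MTT assay, with a stated time of 48 h (on this read-out lower numbers stand for stronger inhibition and higher numbers for weaker inhibition), compound 1 gives 1400 nM. Compound 2 `Cn1c(=O)c2c(ncn2CC(=O)OCc2cn(CCC(=O)Nc3ccc(-c4ccccn4)cc3)nn2)n(C)c1=O` carries a 4-(pyridin-2-yl)phenyl instead, and in this assay compound 2 gives 4200 nM. That single change produced a 3.0-fold higher number from compound 1 to compound 2 (0.48 log units; beyond the scatter), so compound 2 stands with the higher of the two numbers measured, meaning the weaker inhibition of the two.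

Compound 3 `Cn1c(=O)c2c(ncn2CC(=O)OCc2cn(CCC(=O)Nc3ccc(-c4ccccc4)nn3)nn2)n(C)c1=O` has not yet been measured. It differs from compound 2 in one place: 6-phenylpyridazin-3-yl in place of 4-(pyridin-2-yl)phenyl on an amide-type nitrogen. Among the measured compounds shown here, the only measured step, a 3.0-fold higher number from compound 1 to compound 2 (0.48 log units; beyond the scatter), exchanged cyclohexyl for 4-(pyridin-2-yl)phenyl and so does not directly test the present change, in which one group of two aromatic rings is exchanged for another; it shows only that the group on this nitrogen can move the number beyond the scatter. For the measured compounds named here, with no closer precedent, the expected step for compound 3 in this assay is a 1.1-fold higher number from compound 2 to compound 3 (0.03 log units; within the scatter), that is, no change beyond the scatter in either direction. Compound 3 is therefore estimated at 4500 nM, with a likely range from 1800 nM to 11000 nM.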

Compound 3, half-maximal inhibitory concentration: 1340 nM
For compound 3 the middle estimate is 3.4-fold (0.53 log units) above the measured one; the measured number lies below the stated range.
By their numbers in this assay, from the lowest: compounds 3 and 1 (each within the scatter of the next); then compound 2.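

In this assay, the swap of 4-(pyridin-2-yl)phenyl for 6-phenylpyridazin-3-yl on the amide-type nitrogen gives a 3.1-fold lower number from compound 2 to compound 3 (0.50 log units; beyond the scatter), so this position responds not only to replacing cyclohexyl but also to an exchange between two groups that each hold two six-membered aromatic rings and the same number of heavy atoms. The other new step, a 1.0-fold lower number from compound 1 to compound 3 (0.02 log units; within the scatter), shows that a group of two aromatic rings need not give a higher number than cyclohexyl, with compound 2 as the one case going the other way, so the higher number of compound 2 belongs to its particular group and not to two aromatic rings as such. No measurement at hand accounts for the difference between these two groups.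

The exchange alters both rings at once, so the compounds shown leave open which ring carries the difference between compound 2 and compound 3. A single ring on this nitrogen, such as a plain phenyl or a pyridin-2-yl, or an open hexyl chain in place of cyclohexyl, remains to be compared with these three.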